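Compound 3 to compound 4: one ring exchanged

A few compounds are considered here, and "the series" means these few. Any claim that something is new, unique, unknown or untested is made for them only; others in the source may bear on it.

Measured in an ADME assay on MRC5 cells (Homo sapiens) for cytotoxicity, read by MTT assay, with a stated time of 72 h; a higher number here means that more compound is tolerated, a lower number that less compound is tolerated:
compound 1 `OC[C@H]1O[C@@H](n2cc(F)c3c(-c4ccoc4)ncnc32)[C@H](O)[C@@H]1O`: 15400 nM
compound 2 `OC[C@H]1O[C@@H](n2cc(F)c3c(-c4ccc[nH]4)ncnc32)[C@H](O)[C@@H]1O`: 44500 nM
compound 3 `OC[C@H]1O[C@@H](n2cc(F)c3c(-c4cc[nH]c4)ncnc32)[C@H](O)[C@@H]1O`: 48900 nM

Compound 3 stands at the upper end of these numbers, level with compound 2 and clear of compound 1. Compound 4 `OC[C@H]1O[C@@H](n2cc(F)c3c(-c4c[nH]cn4)ncnc32)[C@H](O)[C@@H]1O` carries 1H-imidazol-4-yl in place of 1H-pyrrol-3-yl on an aromatic carbon. Exchanging furan-3-yl for either pyrrole gave modest steps, a 2.9-fold higher number from compound 1 to compound 2 (0.46 log units; beyond the scatter) and a 3.2-fold higher number from compound 1 to compound 3 (0.50 log units; beyond the scatter). Exchanging one pyrrole for the other gave a 1.1-fold higher number from compound 2 to compound 3 (0.04 log units; within the scatter). Within the data shown here, no measured step brings in 1H-imidazol-4-yl, so the guide is indirect, and no step beyond the scatter is expected in this assay, in either direction. The expected step is a 1.0-fold higher number from compound 3 to compound 4 (0.01 log units; within the scatter). Compound 4 is estimated at 50000 nM, with an expected range from 22000 nM to 100000 nM.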

Compound 4, half-maximal cytotoxic concentration: > 50000 nM
Compound 4: only a limit was reported; the forecaster's own chance of this, stated with the estimate: 25%; the middle value sits exactly at the limit.
By their numbers in this assay, from the lowest: compound 1; then compounds 2 and 3 (each within the scatter of the next). At a limit, above all of these: compound 4.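

Compound 4 gives only a limit, not a number: the limit of > 50000 nM in this assay, at which 1 of the 4 values shown sits. So a five-membered ring with two hetero atoms, 1H-imidazol-4-yl, is tolerated on this aromatic carbon without any fall in the number, though the floors against the pyrroles, an at least 1.0-fold higher number from compound 3 to compound 4 (0.00 log units; that floor lies within the scatter) and an at least 1.1-fold higher number from compound 2 to compound 4 (0.05 log units; that floor lies within the scatter), cannot separate it from them. Against furan-3-yl the floor is already clear: an at least 3.2-fold higher number from compound 1 to compound 4 (0.51 log units; beyond the scatter).

On these data alone, how far compound 4 lies past its limit stays open. So does whether a pyridine ring, or an amine or a carboxylic acid on the five-membered ring, would keep the number this high.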